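Swapping a short amine for a guanidine-bearing amide tail

The source may report more compounds than this note shows. Statements on the series, on what has been measured and on what is new or still open speak of the compounds shown alone.

Two pairs of compounds share one structural change, and the question is whether it does the same thing in both. In an ADME assay on cells (Erythrocyte, Homo sapiens), read by hemolysis (a higher number here means that more compound is needed for the effect, a lower number that less compound is needed), compound 1 `CC(C)(C)c1ccc(CC(CN)(Cc2ccc(C(C)(C)C)cc2)C(=O)NCCCN)cc1` gives 254000 nM. Its relative compound 2 `NCCCNC(=O)C(CN)(Cc1ccc2ccccc2c1)Cc1ccc2ccccc2c1` has a different core, and in this assay compound 2 gives 447000 nM, a number within the usual scatter of that of compound 1. The difference between the two cores is not broken down here.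

Compound 3 `CC(C)(C)c1ccc(CC(CN)(Cc2ccc(C(C)(C)C)cc2)C(=O)N[C@@H](CCCNC(=N)N)C(N)=O)cc1` is compound 1 with a larger tail: a group of 11 heavy atoms (6 carbon, 4 nitrogen, 1 oxygen; no ring) in place of a group of 4 heavy atoms (3 carbon, 1 nitrogen; no ring), on an amide-type nitrogen. In this assay compound 3 reaches only a limit of the measurement, > 654000 nM, so no exact number is known for it. The measured step is therefore an at least 2.5-fold higher number from compound 1 to compound 3 (0.41 log units; beyond the scatter), because the value of compound 3 sits at the limit of > 654000 nM in this assay, at which 1 of the 3 values shown sits.

Compound 4 `N=C(N)NCCC[C@H](NC(=O)C(CN)(Cc1ccc2ccccc2c1)Cc1ccc2ccccc2c1)C(N)=O` carries the same change on the core of compound 2: a group of 11 heavy atoms (6 carbon, 4 nitrogen, 1 oxygen; no ring) in place of a group of 4 heavy atoms (3 carbon, 1 nitrogen; no ring), on an amide-type nitrogen. The place described for this change is the same word for word in both pairs, so it counts as the same change. Since the shift in compound 1 was at least modest and ended at a limit, the expectation for compound 4 is a step of similar size, a 2.5-fold higher number from compound 2 to compound 4 (0.39 log units; beyond the scatter), resting on the measured step from compound 1 to compound 3. In this assay compound 4 is thus estimated at 1100000 nM, with a plausible span from 600000 nM to 2500000 nM, and a real chance that the measurement again reports only a limit.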

Compound 4, half-maximal effective concentration: 425000 nM
Compound 4: the middle estimate sits 2.6-fold (0.41 log units) above what was measured, outside the stated range (below it).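

On the core of compound 2, the same swap of the 3-aminopropyl group for the larger tail, on an amide-type nitrogen, gives in this assay a 1.1-fold lower number from compound 2 to compound 4 (0.02 log units; within the scatter), a step too small to tell apart from repeat-to-repeat variation. A change that counts as the same on paper therefore does not carry the same result from one core to the other in this pair of pairs, and the gap between the two steps is larger than their scatter can account for: the same change on two cores in this assay, an at least 2.5-fold higher number (0.41 log units; beyond the scatter) from compound 1 to compound 3 and a 1.1-fold lower number (0.02 log units; within the scatter) from compound 2 to compound 4, at least 2.7-fold (0.43 log units) apart, beyond the scatter of two such steps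

As far as these compounds go, compound 3 gives only a limit, > 654000 nM, so the true size of its step remains unknown, and two pairs of compounds cannot show which part of the cores sets the steps apart or what a further core would do.

The entering tail carries both a guanidine and a carboxamide, and the compounds shown leave open which of the two, if either, matters on each core. A plain 3-guanidinopropyl chain, or the same tail ending in a carboxylic acid instead of the carboxamide, on both cores would help to separate those two parts.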